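A few compounds are considered here, and "the series" means these few. Any claim that something is new, unique, unknown or untested is made for them only; others in the source may bear on it.

Compound 2, `CCCCC(C)(C)OC(=O)CC(=O)Nc1c(C(C)C)cccc1C(C)C`, gives 15 nM in an assay on microsomes from intestine for inhibition of acyl-CoA:cholesterol acyltransferase (Oryctolagus cuniculus) (on this read-out higher numbers stand for weaker inhibition and lower numbers for stronger inhibition), the lower of the two numbers recorded there. Within the data shown here, its neighbour, compound 1, `CCCCCC(C)OC(=O)CC(=O)Nc1c(C(C)C)cccc1C(C)C`, gives 27 nM in this assay, and the single measured step, a 1.8-fold lower number from compound 1 to compound 2 (0.26 log units; within the scatter), does not rise above the scatter. Compound 3, `CC(C)c1cccc(C(C)C)c1NC(=O)CC(=O)OC(C)(C)C`, differs from compound 2 by hydrogen in place of propyl on a saturated chain carbon, two bonds along the chain from an oxygen next to a carbonyl group. Among the measured compounds shown here, no measured pair shows such a shortening of the chain; the one known step concerns only the branching of the chain and was small, so it offers no direct guide to losing a propyl. With the chain cut back this far, compound 3 is expected to give a somewhat higher number, an estimated step of a 2.7-fold higher number from compound 2 to compound 3 (0.43 log units; beyond the scatter). The estimate for compound 3 in this assay is therefore 40 nM, with a range from 12 nM to 140 nM.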

Compound 3, half-maximal inhibitory concentration: 130 nM
Compound 3: middle estimate off by 3.3-fold (0.51 log units), on the low side; the measured number falls inside the stated range.
By their numbers in this assay, from the lowest: compounds 2 and 1 (each within the scatter of the next); then compound 3.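

Cutting the chain back from 1,1-dimethylpentyl to tert-butyl matters in this assay: it gives an 8.7-fold higher number from compound 2 to compound 3 (0.94 log units; beyond the scatter), a clear change at a position where the earlier step, a 1.8-fold lower number from compound 1 to compound 2 (0.26 log units; within the scatter), had shown nothing beyond the scatter. The unbranched end of the chain therefore counts here, and the reading from the other side agrees, with tert-butyl in place of 1-methylhexyl giving a 4.8-fold higher number from compound 1 to compound 3 (0.68 log units; beyond the scatter). No evidence is available that would explain this rise.

The compounds shown leave open how much of the chain is needed, as nothing lies between tert-butyl and the two longer groups, such as 1,1-dimethylpropyl. They also leave open whether a longer chain, such as 1,1-dimethylheptyl, or a chain ending in an amine would keep the number low.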